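Trading 4-Methylcyclohexyl for 4-Methylpiperidin-1-yl on a Carbonyl

The compounds below may be only part of what the source reports. "The series", "measured", "known", "first", "only" and "open" are said of these compounds alone.

Compound 1, `O=C(C1CCCCC1)N1CC(c2nc(-c3cccc(F)c3)no2)C1`: > 10000 nM
Compound 2, `CC1CCC(C(=O)N2CC(c3nc(-c4cccc(Cl)c4)no3)C2)CC1`: > 10000 nM

Both results come from an assay on HEK293 cells for negative allosteric modulation of metabotropic glutamate receptor 5 (Homo sapiens), read by FLIPR; a higher number here means a weaker inhibitor, a lower number a stronger inhibitor. For compound 1 the entry > 10000 nM is a limit of the assay, not a measured number. For compound 2 the entry > 10000 nM is likewise a limit. Compound 2 therefore stands at the edge of what this assay can report, and the whole picture so far is summed up by the limit of > 10000 nM in this assay, at which 2 of the 2 values shown sit. Among the measured compounds shown here, because the two compounds differ in more than one place, no single step between them can be read off.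

Compound 3, `CC1CCN(C(=O)N2CC(c3nc(-c4cccc(Cl)c4)no3)C2)CC1`, is made from compound 2 by one change: 4-methylpiperidin-1-yl in place of 4-methylcyclohexyl on a carbonyl carbon. Since compound 2 gives only a limit in this assay, the step from compound 2 to compound 3 is expected to show no shift beyond the scatter, a number no higher from compound 2 to compound 3 (the limit leaves the size open), with compound 3 most likely again reported only as a limit. Compound 3 is accordingly estimated at 10000 nM, with an expected range from 3000 nM to 30000 nM.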

Compound 3, half-maximal inhibitory concentration: > 10000 nM
Compound 3: no number, only a limit (the forecaster's own chance of this, stated with the estimate: 75%); the middle value lies on the limit itself.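

In this assay compound 3 gives > 10000 nM, which is a limit of the assay and not a number. Among the compounds shown here, compound 2 also gives only a limit, and no step from compound 2 to compound 3 can be read. The compounds shown leave open whether trading 4-methylcyclohexyl for 4-methylpiperidin-1-yl changes inhibition at all, with every value resting at one edge: the limit of > 10000 nM in this assay, at which 3 of the 3 values shown sit.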